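This account rests on a few compounds, and the source may have more. Where it says the series, first, only, none or still open, it means among the compounds named here.

Measured so far:
- compound 1 `CC(C)COC(=O)Nc1ccc([Se]C#N)cc1`: 51200 nM
- compound 2 `Cc1ccc(OC(=O)Nc2ccc([Se]C#N)cc2)cc1`: 44200 nM

In a functional assay on HTB-54 cells (Homo sapiens) for cytotoxicity, read by MTT assay, with a stated time of 72 h (a higher number here means a weaker inhibitor of growth, a lower number a stronger inhibitor of growth), compound 1 gives 51200 nM. In this assay, within the data shown here, compound 2 gives 44200 nM; the two numbers lie within the scatter of one another, so neither stands apart on the series so far.

Compound 3 `CCOC(=O)Nc1ccc([Se]C#N)cc1` differs from compound 1 by methyl in place of isopropyl on a saturated chain carbon bound to an oxygen next to a carbonyl group. Among the measured compounds shown here, no step between two measured compounds bears on this change, and the two numbers in hand give no pull in either direction. The step of a 1.1-fold higher number from compound 1 to compound 3 (0.03 log units; within the scatter) is therefore expected to stay within the scatter. Compound 3 is expected to give 55000 nM in this assay, with a range from 25000 nM to 120000 nM.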

Compound 3, concentration for total growth inhibition: 49300 nM
Beside the measured number, compound 3's estimate is 1.1-fold (0.05 log units) above it, within the range that was stated.
By their numbers in this assay, from the lowest: compounds 2, 3 and 1 (each within the scatter of the next).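

In this assay, among these compounds, the first single-place step is a 1.0-fold lower number from compound 1 to compound 3 (0.02 log units; within the scatter) for methyl in place of isopropyl on a saturated chain carbon bound to an oxygen next to a carbonyl group. At this position, isobutoxy and ethoxy are not told apart by this read-out. No supporting evidence bears on this result.

Open, on these data alone, is whether a longer chain or a terminal amine on this carbon would give a step beyond the scatter. Among the compounds shown here, with only this one step, no trend across chain size can be stated.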